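The source may hold more compounds than are shown below. What is called first, only, known or untested is meant among the compounds shown, and "the series" means these compounds.

Measured in a functional assay on HeLa cells (Homo sapiens) for antiproliferative activity, with a stated time of 5 days (on this read-out higher numbers stand for weaker inhibition and lower numbers for stronger inhibition), compound 1 `O=C1C=CC2(C=C1)OCC(=O)N2c1nc(-c2ccc3c(c2)OCCO3)nn1-c1ccccc1` gives 70 nM and compound 2 `Cc1ccccc1-n1nc(-c2cccc3ccccc23)nc1N1C(=O)COC12C=CC(=O)C=C2` gives 100 nM so the two numbers lie within the scatter of each other. Among the measured compounds shown here, compound 1 therefore stands level with the only other compound measured so far. Compound 3 `O=C1C=CC2(C=C1)OCC(=O)N2c1nc(-c2ccc3ccccc3c2)nn1-c1ccccc1` has not yet been measured. It keeps the core of compound 1 but carries naphthalen-2-yl in place of 2,3-dihydro-1,4-benzodioxin-6-yl on an aromatic carbon and the rest of the structure is unchanged. For the measured compounds named here, no two measured compounds differ in one place only, so the data offer no direct step for this change. Although it differs from compound 1 elsewhere too, compound 2 also bears a naphthalene group on that carbon, and compound 2 gives 100 nM, which lies within the scatter of compound 1. On this limited evidence no step beyond the scatter is expected in this assay and neither direction is favoured. The estimated change a 1.1-fold higher number from compound 1 to compound 3 (0.06 log units; within the scatter) is expected to remain small. For compound 3 the expected value is 80 nM with an estimated range from 30 nM to 220 nM across repeat measurements.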

Compound 3, half-maximal inhibitory concentration: 120 nM
Compound 3: the middle estimate sits 1.5-fold (0.18 log units) below what was measured; measured number inside the range.
By their numbers in this assay, from the lowest: compounds 1, 2 and 3 (each within the scatter of the next).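

In this assay, among the compounds shown here, the exchange of 2,3-dihydro-1,4-benzodioxin-6-yl for naphthalen-2-yl, on the aromatic carbon of the five-membered ring with 3 nitrogen, comes to a 1.7-fold higher number from compound 1 to compound 3 (0.23 log units; within the scatter) and gives the first reading of this change with the rest of the structure held constant. At this position, therefore, the 2 hydrogen-bond acceptors and the non-aromatic ring of the leaving group can be replaced by 2 aromatic rings of carbon only, at the same count of 10 heavy atoms, without a step beyond the scatter. The data on hand offer no independent measurement that would account for this result.

The compounds shown leave open whether this carbon tolerates groups of a different kind, such as an amine, a carboxylic acid or a longer alkyl chain, since both groups compared here are large bicyclic aromatic systems of equal size. They also leave open whether naphthalen-2-yl would give a similar result if a pyridine ring stood in place of the phenyl group on the shared core.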